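The source may report more compounds than this note shows. Statements on the series, on what has been measured and on what is new or still open speak of the compounds shown alone.

Compound 2 `Nc1cc(N)c2nc(-c3ccccc3)c(NCc3ccc(F)cc3)nc2c1` gives 6310 nM in a functional assay on RPMI8266 cells (Homo sapiens) for inhibition, read by sulforhodamine B assay, with a stated time of 48 h (on this read-out lower numbers stand for stronger inhibition of growth and higher numbers for weaker inhibition of growth), and compound 1 `COc1ccc(CNc2nc3cc(N)cc(N)c3nc2-c2ccccc2)cc1OC` gives 7240 nM in this assay, so compound 2 stands alongside compound 1, the two numbers lying within the scatter of each other, as a 1.1-fold lower number from compound 1 to compound 2 (0.06 log units; within the scatter) shows. Compound 3 `Nc1cc(N)c2nc(-c3ccccc3)c(Oc3ccc(F)cc3)nc2c1` differs from compound 2 by 4-fluorophenoxy in place of (4-fluorobenzyl)amino on an aromatic carbon. Among the compounds with values here, the single measured step, a 1.1-fold lower number from compound 1 to compound 2 (0.06 log units; within the scatter), swaps the ring on the saturated chain carbon and keeps the amine linker, so it does not bear on this exchange of the linker itself. Compound 3 is therefore expected to give about 7000 nM, in a range from 2500 nM to 20000 nM. The expected step is a 1.1-fold higher number from compound 2 to compound 3 (0.05 log units; within the scatter), none beyond the scatter, with wide uncertainty.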

Compound 3, concentration for total growth inhibition: 46800 nM
The estimate for compound 3 lay 6.7-fold (0.83 log units) below the measured number; measured number outside the range, above it.
By their numbers in this assay, from the lowest: compounds 2 and 1 (each within the scatter of the next); then compound 3.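

In this assay the exchange on the aromatic carbon next to the ring nitrogen gives a 7.4-fold higher number from compound 2 to compound 3 (0.87 log units; beyond the scatter) and so shows that this position responds to a change of linker, a response that the exchange of the ring on the saturated chain carbon (a 1.1-fold lower number from compound 1 to compound 2 (0.06 log units; within the scatter)) did not show. The exchange also removes the hydrogen-bond donor and the saturated chain carbon together, so this step cannot separate the two. No measurement here explains the step. Left open is whether 4-fluorobenzyloxy, which keeps that carbon with an oxygen linker, or 4-fluorophenylamino, which keeps the nitrogen without that carbon, would stand nearer compound 2 or compound 3.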